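Notes on the step to compound 4

The source may report more compounds than this note shows. Statements on the series, on what has been measured and on what is new or still open speak of the compounds shown alone.

Among the compounds with values here, in a functional assay on RAW264.7 cells (Mus musculus) for inhibition, read by Griess assay, with stated times of 1 h and 24 h (on this read-out higher numbers stand for weaker inhibition and lower numbers for stronger inhibition), compound 1 (`O=C1CC(c2ccccc2OCc2ccc(F)cc2)Oc2ccccc21`) gives 28200 nM and compound 2 (`CC(C)CCOc1ccccc1C1CC(=O)c2ccccc2O1`) gives 39200 nM while compound 3 (`CC(C)c1ccc(COc2ccccc2C2CC(=O)c3ccccc3O2)cc1`) gives 27100 nM on the numbers so far. Compound 3 lies within the scatter of both other compounds, so the three cannot be ranked.

Next in the series is compound 4 (`C=CCOc1ccccc1C1CC(=O)c2ccccc2O1`), with vinyl in place of 4-isopropylphenyl on a saturated chain carbon bound to an oxygen on an aromatic ring.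

Two measured steps fall at this same place. They are a 1.4-fold higher number from compound 1 to compound 2 (0.14 log units; within the scatter) and a 1.4-fold lower number from compound 2 to compound 3 (0.16 log units; within the scatter) and both stay within the scatter. A third step of a 1.0-fold lower number from compound 1 to compound 3 (0.02 log units; within the scatter) with isopropyl in place of fluoro on an aromatic carbon also stays within the scatter. Vinyl itself has not been measured at this place, so the expectation extends beyond the groups tested.

With all three steps this small, no step beyond the scatter is expected in this assay for the new compound. The estimated step is a 1.3-fold higher number from compound 3 to compound 4 (0.11 log units; within the scatter) and carries no firm direction. For compound 4 the expected value is 35000 nM with an estimated range from 18000 nM to 70000 nM in this read-out.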

Compound 4, half-maximal inhibitory concentration: 37800 nM
Beside the measured number, compound 4's estimate is 1.1-fold (0.03 log units) below it; the range from low to high includes it.
By their numbers in this assay, from the lowest: compounds 3, 1, 4 and 2 (each within the scatter of the next).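

In this assay, within the data shown here, the swap of 4-isopropylphenyl for vinyl on the saturated chain carbon bound to an oxygen on an aromatic ring takes away the aromatic ring and leaves 2 heavy atoms in place of 9, and it gives a 1.4-fold higher number from compound 3 to compound 4 (0.14 log units; within the scatter); the earlier steps at this place had only set an aromatic group against isobutyl, so an aromatic ring here now appears dispensable for a reading in this range. The short unsaturated group also cannot be told apart from the other two groups, with a 1.0-fold lower number from compound 2 to compound 4 (0.02 log units; within the scatter) and a 1.3-fold higher number from compound 1 to compound 4 (0.13 log units; within the scatter), so four groups of quite different size at this place give no step beyond the scatter. Nothing at hand bears on why this place tolerates such different groups.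

What the four compounds leave open is whether any group here can move the number beyond the scatter, for instance an amine, a carboxylic acid or a longer chain ending in a hydroxyl group. From the compounds shown here alone, the shared core is the same in all four, so its contribution to the reading remains untested by these compounds.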